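Same Fluoro Step, Second Core, Cytotoxicity Unchanged

The source may hold more compounds than are shown below. What is called first, only, known or untested is meant among the compounds shown, and "the series" means these compounds.

Compound 1 `COc1cccc(S(=O)(=O)/C=C/c2ccccn2)c1` was examined in an ADME assay on BV-2 cells (Mus musculus) for cytotoxicity, with a stated time of 24 h, tested at 10 uM (on this read-out higher numbers stand for a weaker effect at the one concentration tested and lower numbers for a stronger effect), where compound 1 gives 100%. Compound 2 `COc1cccc(S(=O)(=O)/C=C/c2ncccc2F)c1` differs from compound 1 by fluoro in place of hydrogen on an aromatic carbon, and in this assay compound 2 gives 100%; the step of no change at the digits printed from compound 1 to compound 2 (within the scatter). Compound 3 `COc1ccc(S(=O)(=O)/C=C/c2ccccn2)cc1` is built on a second core, and how the core of compound 3 differs from the core of compound 1 is not broken down here. In this assay compound 3 gives 100%, level with compound 1 and compound 2. Compound 4 `COc1ccc(S(=O)(=O)/C=C/c2ncccc2F)cc1`, not yet measured, carries the same change relative to compound 3, namely (fluoro in place of hydrogen on an aromatic carbon), at a place described in the same words as for the pair of compound 1 and compound 2. Going by the values given here, the only guide to what compound 4 will show is the earlier step of no change at the digits printed from compound 1 to compound 2 (within the scatter), which stayed within the scatter. Resting on that, the step of no change at the digits printed from compound 3 to compound 4 (within the scatter) is expected to stay within the scatter as well. In this assay compound 4 is therefore estimated at 100%, with a range from 90% to 105%.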

Compound 4, a percentage reported as activity, at one concentration (the size of the read-out at that concentration, not a potency): 94.2%
The estimate for compound 4 lay 5.8 percentage points above the measured number; measured number inside the range.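

Carried onto the core of compound 3, fluoro in place of hydrogen on an aromatic carbon gives, in this assay, a number 5.8 percentage points lower from compound 3 to compound 4 (within the scatter). Set beside the earlier step, the result does not separate the two cores for this change: the same change on two cores in this assay, no change at the digits printed (within the scatter) from compound 1 to compound 2 and a number 5.8 percentage points lower (within the scatter) from compound 3 to compound 4, 5.8 percentage points apart, within the scatter of two such steps. On these two cores, then, the step stays within the usual scatter at the one concentration tested, but this rests on a single pair per core and does not show that it would stay there on any other core, at another concentration or over another exposure time.

The compounds shown leave open how other groups on the same aromatic carbon, such as chloro, methyl, an amine or a nitrile, would read in this assay. They also leave open what would follow if the methoxy group on the other ring gave way to a carboxylic acid or a longer alkoxy chain.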